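From a Phenylethenyl Arm to a Dimethoxyphenyl Arm

The source may hold more compounds than are shown below. What is called first, only, known or untested is meant among the compounds shown, and "the series" means these compounds.

Of the compounds shown here, three sharing one core have been measured in a functional assay on SNB-75 cells (Homo sapiens) for antiproliferative activity, with a stated time of 48 h; a lower number here means a stronger inhibitor of growth, a higher number a weaker inhibitor of growth. Compound 1 `Cc1cc(O)c(C2=NN(c3ccc(S(N)(=O)=O)cc3)C(c3ccccc3O)C2)cc1Cl` gives 13600 nM. Compound 2 `Cc1cc(O)c(C2=NN(c3ccc(S(N)(=O)=O)cc3)C(c3ccccc3Cl)C2)cc1Cl` carries a chloro in place of the hydroxy on an aromatic carbon and gives 8830 nM; the step is a 1.5-fold lower number from compound 1 to compound 2 (0.19 log units; within the scatter). Compound 3 `Cc1cc(O)c(C2=NN(c3ccc(S(N)(=O)=O)cc3)C(/C=C/c3ccccc3)C2)cc1Cl` carries a 2-phenylethenyl group on the saturated ring carbon and gives 16100 nM. Compound 3 thus holds the highest of the three numbers, but its two neighbours lie close: a 1.2-fold higher number from compound 1 to compound 3 (0.07 log units; within the scatter) and a 1.8-fold higher number from compound 2 to compound 3 (0.26 log units; within the scatter), so none of the three can be set apart from the others on these numbers.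

Compound 4 `COc1ccc(C2CC(c3cc(Cl)c(C)cc3O)=NN2c2ccc(S(N)(=O)=O)cc2)cc1OC` differs from compound 3 at that same saturated ring carbon: 3,4-dimethoxyphenyl in place of 2-phenylethenyl on a saturated ring carbon. The measured steps that bear on this change are the two that already vary this position, from an aryl group to the 2-phenylethenyl group, namely a 1.2-fold higher number from compound 1 to compound 3 (0.07 log units; within the scatter) and a 1.8-fold higher number from compound 2 to compound 3 (0.26 log units; within the scatter). Both were small. Returning to an aryl group, now a 3,4-dimethoxyphenyl, is expected to bring the number back toward those of compound 1 and compound 2, and the change is therefore expected to be a 1.5-fold lower number from compound 3 to compound 4 (0.17 log units; within the scatter). On that basis compound 4 is estimated at 11000 nM, with a range from 5000 nM to 25000 nM.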

Compound 4, concentration for total growth inhibition: 97200 nM
Compound 4: middle estimate off by 8.8-fold (0.95 log units), on the low side; measured number above the stated range.
By their numbers in this assay, from the lowest: compounds 2, 1 and 3 (each within the scatter of the next); then compound 4.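

In this assay, the saturated ring carbon no longer looks indifferent to its substituent, since the three earlier groups gave steps within the scatter, whereas 3,4-dimethoxyphenyl gives a 6.0-fold higher number from compound 3 to compound 4 (0.78 log units; beyond the scatter), a 7.1-fold higher number from compound 1 to compound 4 (0.85 log units; beyond the scatter) and an 11-fold higher number from compound 2 to compound 4 (1.04 log units; beyond the scatter). Compound 1, compound 2 and compound 4 all carry a substituted phenyl ring directly on this carbon, yet compound 4 is the weakest inhibitor of growth of the four, so the presence of such a ring does not by itself keep the number near those of compound 1 and compound 2, and the change from 2-phenylethenyl to an aryl group does not by itself lower it. Nothing available here accounts for the size of this rise.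

The compounds shown leave open whether the rise comes from the pair of methoxy groups or from just one of them, which a phenyl ring bearing a single methoxy group or an unsubstituted phenyl ring at this carbon would help to separate. They also leave open whether other groups on the ring, such as a dimethylamino group or a carboxylic acid, would give a similar rise.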